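The source may hold more compounds than are shown below. What is called first, only, known or untested is meant among the compounds shown, and "the series" means these compounds.

Three compounds with a long saturated chain on a small nitrogen-bearing core have been tested. Compound 1 `CCCCCCCCCCn1c(N)c(N)c(=O)[nH]c1=O` gives 280 nM in a functional assay (mitochondria, heart) with Bos taurus as the target; a higher number here means a weaker inhibitor, a lower number a stronger inhibitor. Compound 2 `CCCCCCCCCCCCn1c(=O)[nH]c(N)c(N)c1=O` gives 260 nM in this assay. Compound 3 `CCCCCCCCCCCCNc1nc(O)nc(O)c1N` gives 300 nM in this assay. Compound 3 thus carries the highest of the three numbers, yet its gap to compound 1 and its gap to compound 2 both fall within the scatter of repeated measurements, so the three compounds cannot be told apart on these data.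

Compound 4 `CCCCCCCCCCCCCCCCNc1nc(O)nc(O)c1N` is the next compound. It differs from compound 3 by butyl in place of hydrogen on a saturated chain carbon, ten or more bonds along the chain from a nitrogen on an aromatic ring. Among the compounds with values here, no pair of measured compounds differs in only one place, so there is no direct measure of what lengthening the chain does here. Compound 1 and compound 2 carry chains of different length on different cores and sit within the scatter of each other, which gives no sign that chain length moves the number. The step from compound 3 to compound 4 is therefore expected to be a 1.1-fold higher number from compound 3 to compound 4 (0.03 log units; within the scatter), that is, none beyond the scatter in either direction. Compound 4 is estimated to give 320 nM in this assay, with a range from 110 nM to 950 nM.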

Compound 4, half-maximal inhibitory concentration: 900 nM
Estimate against measurement, compound 4: 2.8-fold (0.45 log units) below; the measured number falls inside the stated range.
By their numbers in this assay, from the lowest: compounds 2, 1 and 3 (each within the scatter of the next); then compound 4.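

In this assay, butyl in place of hydrogen on a saturated chain carbon, ten or more bonds along the chain from a nitrogen on an aromatic ring, gives a 3.0-fold higher number from compound 3 to compound 4 (0.48 log units; beyond the scatter), the first difference in this set that stands clear of the scatter. This far out along the chain, then, the position is not silent: the longer chain on this core goes with a weaker inhibitor, something the three earlier compounds, which could not be told apart, gave no sign of. Nothing available explains why the longer chain gives the weaker inhibitor.

This single pair cannot say whether the number climbs evenly as the chain grows or changes only beyond a certain length, nor whether a shorter chain such as octyl on the same core would sit with compound 3 or move the other way. It also leaves open whether the same lengthening would act alike on the cores of compound 1 and compound 2, and whether an amine or a carboxylic acid at the end of the chain would change the outcome.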